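The compounds below may be only part of what the source reports. "The series", "measured", "known", "first", "only" and "open" are said of these compounds alone.

Measured compounds in an assay on HEK293 cells for displacement of a labelled ligand from growth hormone secretagogue receptor type 1 (Homo sapiens), with a stated time of 60 min; on this read-out higher numbers stand for weaker inhibition and lower numbers for stronger inhibition:
- compound 1, `Cc1cc(C)n(-c2ccc(Cl)c(C(=O)NC(=O)Nc3nc4ccc(S(=O)(=O)CCCN5CCN(C)CC5)cc4s3)c2)n1`: 1.3 nM
- compound 2, `CN1CCN(CCCS(=O)(=O)c2ccc3nc(NC(=O)NC(=O)c4cc(N5CCCC5)ccc4Cl)sc3c2)CC1`: 0.29 nM
- compound 3, `CN1CCN(CCCS(=O)(=O)c2ccc3nc(NC(=O)NC(=O)c4cc5c(ccn5C)cc4Cl)sc3c2)CC1`: 0.57 nM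

On these three numbers compound 3 stands second highest. Its nearest neighbour is compound 2, and the two lie within the scatter of each other, as the step of a 2.0-fold higher number from compound 2 to compound 3 (0.29 log units; within the scatter) shows. Its furthest neighbour is compound 1, whose number is higher than that of compound 3 and beyond the scatter.

Compound 4, `CCOc1ccc(Cl)c(C(=O)NC(=O)Nc2nc3ccc(S(=O)(=O)CCCN4CCN(C)CC4)cc3s2)c1`, differs from compound 3 in one place: 2-chloro-5-ethoxyphenyl in place of 5-chloro-1-methyl-1H-indol-6-yl on a carbonyl carbon. Among the measured compounds shown here, two measured steps bear on this change. The step of a 4.5-fold lower number from compound 1 to compound 2 (0.65 log units; beyond the scatter) shows that swapping one group on the aromatic carbon of the chlorophenyl ring can shift this assay modestly. The step of a 2.0-fold higher number from compound 2 to compound 3 (0.29 log units; within the scatter) shows that exchanging the whole chlorophenyl unit for the indolyl unit stays within the scatter. For the measured compounds named here, compound 4 brings back a chlorophenyl unit, now carrying an ethoxy group, which has no measured counterpart here. The expected step of a 1.4-fold higher number from compound 3 to compound 4 (0.15 log units; within the scatter) is therefore small, in either direction or none beyond the scatter. Compound 4 is estimated at 0.8 nM, with a range from 0.25 nM to 2.5 nM.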

Compound 4, half-maximal inhibitory concentration in the growth hormone secretagogue receptor type 1 assay: 0.31 nM
Beside the measured number, compound 4's estimate is 2.6-fold (0.41 log units) above it; the measured number falls inside the stated range.
By their numbers in the growth hormone secretagogue receptor type 1 assay, from the lowest: compounds 2, 4 and 3 (each within the scatter of the next); then compound 1.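

At this aromatic carbon, the growth hormone secretagogue receptor type 1 assay does not separate ethoxy from pyrrolidin-1-yl (a 1.1-fold higher number from compound 2 to compound 4 (0.03 log units; within the scatter)), and it does not separate the 2-chloro-5-ethoxyphenyl unit from the 5-chloro-1-methyl-1H-indol-6-yl unit (a 1.8-fold lower number from compound 3 to compound 4 (0.26 log units; within the scatter)). Only 3,5-dimethyl-1H-pyrazol-1-yl stands apart from ethoxy in the growth hormone secretagogue receptor type 1 assay (a 4.2-fold lower number from compound 1 to compound 4 (0.62 log units; beyond the scatter)), as it does from pyrrolidin-1-yl. The change from compound 3 to compound 4 stays within the scatter in the growth hormone secretagogue receptor type 1 assay yet registers in a physicochemical assay for lipophilicity; on this read-out higher numbers stand for higher lipophilicity and lower numbers for lower lipophilicity: the measured distribution coefficient of compound 3, 2.8, and of compound 4, 2.4, a number 0.40 log units lower (beyond the scatter). In the physicochemical assay compound 3 gives 2.8 and compound 4 gives 2.4.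

The compounds shown leave open whether a shorter or longer chain on this aromatic carbon, such as methoxy or propoxy, would sit with ethoxy. They also leave open whether an open-chain amine such as dimethylamino would sit with pyrrolidin-1-yl.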